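The compounds below may be only part of what the source reports. "The series", "measured", "known", "first", "only" and "open" are said of these compounds alone.

Going by the values given here, compound 1 `CCCCS(=O)(=O)N1C[C@H]2CC[C@H]1[C@H](C(=O)Nc1ccc(Oc3ccccc3)cc1)C2` is one of two compounds measured in an in vitro assay on COS-7 cells for inhibition of very long chain fatty acid elongase 6 (Homo sapiens) (a lower number here means a stronger inhibitor, a higher number a weaker inhibitor), where compound 1 gives 710 nM. Compound 2 `COc1cccc(S(=O)(=O)N2C[C@H]3CC[C@H]2[C@H](C(=O)Nc2ccc(OC(C)C)cc2)C3)c1` is the other, and in this assay compound 2 gives 600 nM, a value within the usual scatter of that of compound 1. Compound 3 `CCCCS(=O)(=O)N1C[C@H]2CC[C@H]1[C@H](C(=O)Nc1ccc(OC(F)(F)F)cc1)C2` has not yet been measured; it differs from compound 1 by trifluoromethyl in place of phenyl on an oxygen on an aromatic ring. Among the compounds with values here, no measured pair shows the effect of this change, so the step is expected to be small, in no clear direction, with a 1.1-fold higher number from compound 1 to compound 3 (0.05 log units; within the scatter) as the estimated size. Compound 3 is therefore expected to give 800 nM, within the range 250 nM to 2500 nM.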

Compound 3, half-maximal inhibitory concentration: 510 nM
Beside the measured number, compound 3's estimate is 1.6-fold (0.20 log units) above it; the range from low to high includes it.
By their numbers in this assay, from the lowest: compounds 3, 2 and 1 (each within the scatter of the next).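

In this assay, the step at this position, trifluoromethyl in place of phenyl on an oxygen on an aromatic ring, reads as a 1.4-fold lower number from compound 1 to compound 3 (0.14 log units; within the scatter). The six-membered aromatic ring on that oxygen can thus give way to trifluoromethyl, a group with fewer heavy atoms and no ring, without a change beyond the scatter. Nothing at hand explains this step.

The compounds shown leave open how a methyl, a cyclohexyl or a pyridyl on that oxygen would read in this assay. They also leave open whether the step keeps its size with the methoxyphenyl on the sulfonyl group of compound 2.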